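Removing a Dimethylamino Group on Two Different Cores

The source may report more compounds than this note shows. Statements on the series, on what has been measured and on what is new or still open speak of the compounds shown alone.

Compound 1 `Cc1ccc(Nc2ncc3c(n2)N(C)C(=O)N(c2cc(NC(=O)c4cccc(C(F)(F)F)c4)ccc2C)C3)cc1` and compound 2 `Cc1ccc(Nc2ncc3c(n2)N(C)C(=O)N(c2cc(NC(=O)c4cccc(C(F)(F)F)c4)ccc2C)C3)cc1N(C)C` share one core, while compound 3 `Cc1ccc(Nc2ncc(C(=O)Nc3cc(NC(=O)c4cccc(C(F)(F)F)c4)ccc3C)c(N(C)C)n2)cc1N` is built on another; the difference between the two cores is not broken down here. In a functional assay on K562 cells (Homo sapiens) for antiproliferative activity, read by CellTiter-Glo and CCK-8 assay, with a stated time of 72 h (a higher number here means a weaker inhibitor of growth, a lower number a stronger inhibitor of growth), compound 1 gives 18 nM, compound 2 gives 28 nM, and compound 3 gives 1210 nM, the highest of the three. Compound 2 becomes compound 1 through (hydrogen in place of dimethylamino on an aromatic carbon), and this gave a 1.6-fold lower number from compound 2 to compound 1 (0.19 log units; within the scatter). Compound 4 `Cc1ccc(Nc2ncc(C(=O)Nc3cc(NC(=O)c4cccc(C(F)(F)F)c4)ccc3C)cn2)cc1N` has not been measured; it arises from compound 3 through (hydrogen in place of dimethylamino on an aromatic carbon). This is the same kind of change, but the place differs: in compound 2 it sits on a ring of carbon only, ortho to a methyl group and meta to a large group, whereas in compound 3 it sits on a ring with 2 nitrogen, next to the ring nitrogen, ortho to a large group and meta to a (3-amino-4-methylphenyl)amino group. Among the measured compounds shown here, the only guide is the step from compound 2 to compound 1, which stayed within the scatter. Compound 4 is therefore expected to give about 1500 nM in this assay, likely between 500 nM and 5000 nM. This expectation means a step of a 1.2-fold higher number from compound 3 to compound 4 (0.09 log units; within the scatter), with wide bounds since the core differs.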

Compound 4, concentration for 50% growth inhibition: 330 nM
For compound 4 the middle estimate is 4.5-fold (0.66 log units) above the measured one; the measured number lies below the stated range.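

In this assay, putting hydrogen in place of dimethylamino on the second core gave a 3.7-fold lower number from compound 3 to compound 4 (0.56 log units; beyond the scatter). Set beside the same change on the first core, this step cannot be told apart from the earlier one: the same change on two cores in this assay, a 1.6-fold lower number (0.19 log units; within the scatter) from compound 2 to compound 1 and a 3.7-fold lower number (0.56 log units; beyond the scatter) from compound 3 to compound 4, 2.4-fold (0.37 log units) apart, within the scatter of two such steps. This shows that the two cores gave compatible results for this one change, but two pairs do not show that its size carries over reliably to other cores in this series.

The compounds shown leave open how other groups at this place, such as a methoxy group or a longer dialkylamine, would compare with dimethylamino and hydrogen. They also leave open how much the difference between the two cores itself contributes to growth inhibition.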